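This account rests on a few compounds, and the source may have more. Where it says the series, first, only, none or still open, it means among the compounds named here.

Compound 1 `Cc1cc(C)c(S(C)(=O)=O)cc1C(=O)N=C(N)N` gives 11 nM in a functional assay for inhibition of sodium/hydrogen exchanger (Oryctolagus cuniculus); on this read-out lower numbers stand for stronger inhibition and higher numbers for weaker inhibition.
Compound 2 `Cc1cc(-c2cc(Cl)cc(Cl)c2)c(S(C)(=O)=O)cc1C(=O)N=C(N)N` gives 130 nM.
Compound 3 `CCSc1cc(C)c(C(=O)N=C(N)N)cc1S(C)(=O)=O` gives 5.9 nM.

On the numbers shown, compound 3 stands at the low end, with compound 1 within the scatter of it and compound 2 far above. Compound 4 `Cc1cc(Sc2ccccc2)c(S(C)(=O)=O)cc1C(=O)N=C(N)N` differs from compound 3 by phenyl in place of ethyl on a sulfur, so that ethylsulfanyl becomes phenylsulfanyl. Within the data shown here, two steps bear on this. Bringing an aromatic ring onto the core gave a 12-fold higher number from compound 1 to compound 2 (1.07 log units; beyond the scatter), and swapping that ring for the short chain gave a 22-fold lower number from compound 2 to compound 3 (1.34 log units; beyond the scatter); the smaller change of a 1.9-fold lower number from compound 1 to compound 3 (0.27 log units; within the scatter) stayed within the scatter. A ring entering again, now on the sulfur, is therefore expected to raise the number, though perhaps by less than before. Compound 4 is estimated at 30 nM, between 8 nM and 120 nM. This expected step is a 5.1-fold higher number from compound 3 to compound 4 (0.71 log units; beyond the scatter).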

Compound 4, half-maximal inhibitory concentration: 14 nM
Compound 4: middle estimate off by 2.1-fold (0.33 log units), on the high side; low and high end bracket the measured number.
By their numbers in this assay, from the lowest: compounds 3, 1 and 4 (each within the scatter of the next, the first and the last beyond it); then compound 2.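

A ring at this position does not by itself bring a large penalty: phenylsulfanyl in place of 3,5-dichlorophenyl gives a 9.3-fold lower number from compound 2 to compound 4 (0.97 log units; beyond the scatter) and so recovers most of what compound 2 lost. Set against the small methyl, phenylsulfanyl gives a 1.3-fold higher number from compound 1 to compound 4 (0.10 log units; within the scatter) and stays within the scatter. On the sulfur, phenyl in place of ethyl gives only a 2.4-fold higher number from compound 3 to compound 4 (0.38 log units; beyond the scatter) and is a modest step.

As far as these compounds go, whether the chlorines or the sulfur accounts for the difference from compound 2 stays open, as does how an amine or a carboxylic acid on this aromatic carbon would compare. No measurement offered here explains the size of these steps.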